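A few compounds are considered here, and "the series" means these few. Any claim that something is new, unique, unknown or untested is made for them only; others in the source may bear on it.

Compounds measured in a functional assay on HL-60 cells (Homo sapiens) for antiproliferative activity, read by MTT assay, with a stated time of 48 h; on this read-out lower numbers stand for stronger inhibition and higher numbers for weaker inhibition:
- compound 1 `CC(C)=CCC[C@]1(C)/C=C/[C@@H](OC(=O)C=C(C)C)[C@](C)(O)/C=C/C(=O)/C(C(=O)O)=C\C1` — > 10000 nM
- compound 2 `CC(C)=CCC[C@]1(C)/C=C/[C@@H](OC(=O)C=C(C)C)[C@](C)(O)/C=C/[C@H](O)/C(CO)=C\C1` — > 40000 nM
- compound 3 `CC(C)=CCC[C@](C)(/C=C/[C@@H](OC(=O)C=C(C)C)[C@](C)(O)/C=C/C(=O)/C=C/N1CCN(C)CC1)CC=O` — 1060 nM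

Compound 1 gives only a limit in this assay, > 10000 nM, which is a boundary of the measurement and not a number. Compound 2 also gives only a limit, > 40000 nM. Compound 3 gives a number, 1060 nM. Compound 1 therefore stands at the limit of > 10000 nM in this assay, at which 1 of the 3 values shown sits, the weaker end of what is shown.

Compound 4 `CCN(CC)C(=O)/C1=C/C[C@](C)(CCC=C(C)C)/C=C/[C@@H](OC(=O)C=C(C)C)[C@](C)(O)/C=C/C1=O` has not yet been measured. It differs from compound 1 in one place: diethylamino in place of hydroxy on a carbonyl carbon. Among the measured compounds shown here, no measured pair shows this change, so the size of the step is open. The replacement of the carboxy by diethylcarbamoyl is expected to bring a modest move toward stronger inhibition, an at least 1.6-fold lower number from compound 1 to compound 4 (0.22 log units; that floor lies within the scatter). Compound 4 is estimated at 6000 nM, between 1500 nM and 25000 nM.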

Compound 4, half-maximal inhibitory concentration: 9080 nM
Estimate against measurement, compound 4: 1.5-fold (0.18 log units) below; the measured number falls inside the stated range.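

Putting diethylamino in place of hydroxy on a carbonyl carbon gives, in this assay, an at least 1.1-fold lower number from compound 1 to compound 4 (0.04 log units; that floor lies within the scatter), so this position tolerates the change and the result is a readable number rather than a limit. That step is only a floor, and it establishes no real gain in strength. Its true size stays unknown because compound 1 sits at a limit: the limit of > 10000 nM in this assay, at which 1 of the 4 values shown sits.

On these data alone, whether methoxy or dimethylamino on the same carbonyl carbon would read any differently remains open. So does the question of whether a ring amine such as piperidine would behave like diethylamino there.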